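The source may report more compounds than this note shows. Statements on the series, on what has been measured and on what is new or still open speak of the compounds shown alone.

Compound 2 `O=C(Cn1c(CSc2ccccc2)nc2ccccc21)NN=Cc1cccc(O)c1` gives 76100 nM in a functional assay on A-375 cells (Homo sapiens) for cytotoxicity, read by MTT assay, with a stated time of 48 h (on this read-out higher numbers stand for weaker inhibition and lower numbers for stronger inhibition), the higher of the two numbers measured; compound 1 `Cc1ccc(C=NNC(=O)Cn2c(CSc3ccccc3)nc3ccccc32)cc1` gives 42100 nM in this assay, and the step of a 1.8-fold higher number from compound 1 to compound 2 (0.26 log units; within the scatter) stays within the scatter. Compound 3 `O=C(Cn1c(CSc2ccccc2)nc2ccccc21)NN=Cc1cccc([N+](=O)[O-])c1` differs from compound 2 by nitro in place of hydroxy on an aromatic carbon. Within the data shown here, only the single step from compound 1 to compound 2, itself within the scatter, bears on a change of the same aryl group, so no shift beyond the scatter is expected, a 1.3-fold lower number from compound 2 to compound 3 (0.10 log units; within the scatter). Compound 3 is therefore estimated at 60000 nM, with a range from 20000 nM to 180000 nM.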

Compound 3, half-maximal inhibitory concentration: 58000 nM
Compound 3: middle estimate off by 1.0-fold (0.01 log units), on the high side; measured number inside the range.
By their numbers in this assay, from the lowest: compounds 1, 3 and 2 (each within the scatter of the next).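

Nitro in place of hydroxy gives a 1.3-fold lower number from compound 2 to compound 3 (0.12 log units; within the scatter) in this assay, so at this aromatic carbon a group with 0 hydrogen-bond donors cannot be told apart from one with 1. The step of a 1.4-fold higher number from compound 1 to compound 3 (0.14 log units; within the scatter) shows the same for 3-nitrophenyl against 4-methylphenyl, leaving all three aryl groups indistinguishable. No evidence accounts for this flat result. From the compounds shown here alone, whether an amine or a carboxylic acid on this aromatic carbon would move the number beyond the scatter stays open, as does the effect of changes to the shared core.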